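The compounds below may be only part of what the source reports. "The series", "measured", "known", "first", "only" and "open" are said of these compounds alone.

Measured in an ADME assay on microsomes from liver (Rattus norvegicus) for metabolic stability, read by LC-MS, with a stated time of 30 min, tested at 0.5 uM; on this read-out lower numbers stand for a less stable compound and higher numbers for a more stable compound:
compound 1 `Oc1cccc(-c2nc(-c3csc(N=C4NCCCN4)n3)cs2)c1`: 35%
compound 2 `Oc1ccccc1-c1nc(-c2csc(N=C3NCCCN3)n2)cs1`: 38%
compound 3 `c1cc(-c2nc(-c3csc(N=C4NCCCN4)n3)cs2)ccn1`: 9%

Compound 3 stands lowest of the three, and its distance to each of the other two lies beyond the scatter. Compound 4 `c1cncc(-c2nc(-c3csc(N=C4NCCCN4)n3)cs2)c1` has the same atoms as compound 3, joined differently: pyridin-3-yl in place of pyridin-4-yl on an aromatic carbon. Pyridin-3-yl stands in place of pyridin-4-yl on an aromatic carbon.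

Going by the values given here, no measured step exchanges one of these groups for the other. The closest parallel is the exchange of 3-hydroxyphenyl for 2-hydroxyphenyl, a number 3 percentage points higher from compound 1 to compound 2 (within the scatter), which stayed within the scatter. Among the compounds with values here, two larger steps, a number 26 percentage points lower from compound 1 to compound 3 (beyond the scatter) and a number 29 percentage points lower from compound 2 to compound 3 (beyond the scatter), replace a hydroxyphenyl group with pyridin-4-yl, a different kind of change from the one in compound 4. A step beyond the scatter is therefore not expected in this assay, though a small rise seems more likely than a fall, given that compound 3 has only 9%.

The expected change is a number 5 percentage points higher from compound 3 to compound 4 (within the scatter). Compound 4 is estimated at 14%, with an expected range from 4% to 32%.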

Compound 4, percent of the compound remaining: 19%
Compound 4: middle estimate off by 5 percentage points, on the low side, within the range that was stated.
By their numbers in this assay, from the lowest: compounds 3 and 4 (each within the scatter of the next); then compounds 1 and 2 (each within the scatter of the next).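

In this assay, pyridin-3-yl in place of pyridin-4-yl at this position gives a step that does not separate the two pyridines (a number 10 percentage points higher from compound 3 to compound 4 (within the scatter)). The gap to the hydroxyphenyl compounds, earlier seen only for pyridin-4-yl, now also holds for pyridin-3-yl (a number 16 percentage points lower from compound 1 to compound 4 (beyond the scatter); a number 19 percentage points lower from compound 2 to compound 4 (beyond the scatter)), and among these four compounds none goes against this split by ring type. Nothing shown explains this split or says what lies behind the values.

From the compounds shown here alone, it remains open whether pyridin-2-yl would stand with the other two pyridines, and whether an unsubstituted phenyl or a methoxyphenyl would stand with the pyridines or with the hydroxyphenyl compounds. The compounds also leave open how an amine or a carboxylic acid on the pyridine ring would read in this assay.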